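The compounds below may be only part of what the source reports. "The series", "measured", "known", "first", "only" and "open" are said of these compounds alone.

In a functional assay on MGC-803 cells (Homo sapiens) for cytotoxicity, read by MTT assay, with a stated time of 38 h (a higher number here means a weaker inhibitor, a lower number a stronger inhibitor), compound 1 `COc1cc(OC)c2c(=O)c(OCC(=O)N/N=C/c3ccc[nH]3)c(-c3cc(OC)c(OC)c(OC)c3)oc2c1` gives 5610 nM and compound 2 `CCN(CC)CCCOc1c(-c2cc(OC)c(OC)c(OC)c2)oc2cc(OC)cc(OC)c2c1=O` gives 40200 nM as the higher of the two numbers. The change to compound 3 `COc1cc(OC)c2c(=O)c(OCC(=O)N/N=C/c3ccccn3)c(-c3cc(OC)c(OC)c(OC)c3)oc2c1` removes the 2-(diethylamino)ethyl and is counted as a group of 11 heavy atoms (7 carbon, 3 nitrogen, 1 oxygen; one six-membered aromatic ring with 1 hetero atom) in place of a group of 7 heavy atoms (6 carbon, 1 nitrogen; no ring), on a saturated chain carbon bound to an oxygen on an aromatic ring on a saturated chain carbon bound to an oxygen on an aromatic ring. Going by the values given here, the one measured step bearing on this, a 7.2-fold higher number from compound 1 to compound 2 (0.86 log units; beyond the scatter) as a modest move beyond the scatter, has a group with an aromatic ring leaving and the 2-(diethylamino)ethyl entering, so the change here runs the other way. A step of similar size towards a lower number is expected in this assay (estimated as a 6.7-fold lower number from compound 2 to compound 3 (0.83 log units; beyond the scatter)). For compound 3 the estimated value is 6000 nM (expected range 1800 nM to 20000 nM).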

Compound 3, half-maximal inhibitory concentration: 15300 nM
Compound 3: middle estimate off by 2.6-fold (0.41 log units), on the low side, within the range that was stated.
By their numbers in this assay, from the lowest: compound 1; then compound 3; then compound 2.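

Within this assay, the ring at the end of the chain matters on its own: with pyridin-2-yl in place of 1H-pyrrol-2-yl on a carbon with a double bond to nitrogen, there is a 2.7-fold higher number from compound 1 to compound 3 (0.44 log units; beyond the scatter), so this change alone moves the number. Even so, the pyridin-2-yl group keeps an advantage over the 2-(diethylamino)ethyl group, with a 2.6-fold lower number from compound 2 to compound 3 (0.42 log units; beyond the scatter), so both ring-bearing chains sit below the amine chain. Nothing available explains the difference between the two rings.

Still open, on these data alone, is whether a plain phenyl or a furan-2-yl ring on that carbon would fall nearer the pyrrole or the pyridine. Also open, as far as these compounds go, is how a morpholine in place of the diethylamino end would rank.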